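From phenyl to 4-fluorophenyl: compound 2 to compound 3

The source may hold more compounds than are shown below. What is called first, only, known or untested is meant among the compounds shown, and "the series" means these compounds.

Among the compounds with values here, in a physicochemical assay for lipophilicity, at pH 7.4 (a higher number here means a more lipophilic compound, a lower number a more polar compound), compound 2 (`CNC(=O)c1cc(C(=O)NC2CC2)cc2c1OC[C@H]2c1ccccc1`) gives 3.6 and compound 1 (`CNC(=O)c1cc(C(=O)NC2CC2)cc2c1OC[C@H]2c1cccc(OC)c1`) gives 3.8 as its only neighbour on the scale. These two values lie within the scatter of each other, so neither compound can be set apart from the other.

Compound 3 (`CNC(=O)c1cc(C(=O)NC2CC2)cc2c1OC[C@H]2c1ccc(F)cc1`) has fluoro in place of hydrogen on an aromatic carbon, para to a large group, which turns phenyl into 4-fluorophenyl (fluoro in place of hydrogen on an aromatic carbon).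

Within the data shown here, only one measured step bears on this change: hydrogen in place of methoxy on an aromatic carbon (a number 0.20 log units lower from compound 1 to compound 2 (within the scatter)). Among the measured compounds shown here, it involves a different group, and no measured compound carries fluoro, so it is only a rough guide. Since that step (a number 0.20 log units lower from compound 1 to compound 2 (within the scatter)) stayed small, a small upward step at most is expected here, with nothing beyond the scatter in this assay.

The expected step is small (a number 0.10 log units higher from compound 2 to compound 3 (within the scatter)) and stays within the scatter. The estimated value for compound 3 is 3.7 with an expected range from 3.4 to 4 for a single measurement.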

Compound 3, distribution coefficient: 3.8
Estimate against measurement, compound 3: 0.10 log units below; the range from low to high includes it.
By their numbers in this assay, from the lowest: compounds 2, 1 and 3 (each within the scatter of the next).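

Fluoro on this ring now has a measured step: in this assay, placing it on an aromatic carbon para to a large group gives a number 0.20 log units higher from compound 2 to compound 3 (within the scatter), so this replacement of hydrogen cannot be told apart from no change. Exchanging the whole aryl group on the saturated ring carbon gives no change at the digits printed from compound 1 to compound 3 (within the scatter), so 4-fluorophenyl and 3-methoxyphenyl are not separated here either, and all three steps shown for these groups on the shared core stay within the scatter, with no compound going against this. Nothing at hand accounts for these values.

Still open, going by these compounds, is whether an entirely different kind of group at this ring position, such as an amine or a carboxylic acid, would give a step beyond the scatter in this assay. The compounds shown also leave open whether fluoro at another carbon of the ring, or a larger halogen such as bromo at the same carbon, would stay as close to compound 2 as compound 3 does.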